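The source may hold more compounds than are shown below. What is called first, only, known or untested is meant among the compounds shown, and "the series" means these compounds.

Measured compounds:
Compound 1 `COc1cc(C)cc(-c2c(-c3ccnc(-c4ccc(N(C)C)cc4)c3)cnn2CC#N)c1` gives 12% in a functional assay on OVCAR-8 cells (Homo sapiens) for cytotoxicity, read by sulforhodamine B assay, with a stated time of 48 h, tested at 1 uM; on this read-out lower numbers stand for a stronger effect and higher numbers for a weaker effect at the one concentration tested.
Compound 2 `Cc1cc(O)cc(-c2nn(CC#N)cc2-c2ccnc(-c3ccc(N(C)C)cc3)c2)c1` gives 27% in this assay.

Of these two numbers, compound 1 holds the lowest, and on this read-out a lower number stands for a stronger effect at the one concentration tested. Its nearest neighbour is compound 2, whose number sits higher by a margin that lies beyond the usual scatter of repeated measurements. Among the compounds with values here, no pair of measured compounds differs in one place only, so no single measured step is available to lean on.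

Compound 3 `COc1cc(C)cc(-c2c(-c3ccnc(-c4ccc(C(C)=O)cc4)c3)cnn2CC#N)c1` has not yet been measured. It differs from compound 1 in one place: acetyl in place of dimethylamino on an aromatic carbon. Within the data shown here, nothing among the measured compounds tells what this exchange does, so the expectation must stay open and wide. The step from compound 1 to compound 3 in this assay is expected to be modest and upward, toward a weaker effect, though it could also fall within the scatter; it is estimated as a number 18 percentage points higher from compound 1 to compound 3 (beyond the scatter). Compound 3 is therefore expected to give about 30%, with a plausible range from 10% to 60%.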

Compound 3, a percentage reported as activity, at one concentration (the size of the read-out at that concentration, not a potency): 8%
Compound 3: the middle estimate sits 22 percentage points above what was measured; measured number below the stated range.
By their numbers in this assay, from the lowest: compounds 3 and 1 (each within the scatter of the next); then compound 2.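

Replacing dimethylamino with acetyl on the aromatic carbon para to a large group gives, in this assay, a number 4 percentage points lower from compound 1 to compound 3 (within the scatter), so this exchange cannot be told apart from no change at all. Within the data shown here, the earlier compounds offered no single-place comparison, and this pair is the first to show that the 4-(dimethylamino)phenyl group can give way to 4-acetylphenyl without a measurable loss of effect at the one concentration tested. Nothing shown explains why two groups of the same heavy-atom count, one carrying nitrogen and the other a carbonyl, read alike here.

On these data alone, whether this position would tolerate just any group remains open: a bare hydrogen, a primary amine, a carboxylic acid or a longer alkyl chain could each read quite differently from acetyl and dimethylamino. Because the read-out gives the size of the effect at one concentration and not a potency, the pair also leaves open whether the two compounds would still match at lower concentrations.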